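The compounds below may be only part of what the source reports. "The series", "measured", "known", "first", "only" and "open" are said of these compounds alone.

Series notes. Compound 1 `O=C(Nc1ccc(Cl)c(-c2nnc3c(Cl)cccn23)c1)c1cccc(Cl)c1` carries a 3-chlorophenyl on the carbonyl carbon. In a functional assay on HeLa cells (Homo sapiens) for antiproliferative activity, read by MTT assay, with a stated time of 72 h (a higher number here means a weaker inhibitor, a lower number a stronger inhibitor), compound 1 gives > 100000 nM, which is a limit of the assay and not a number. Compound 2 `O=C(Nc1ccc(Cl)c(-c2nnc3c(Cl)cccn23)c1)c1ccc(Cl)cc1Cl` carries a 2,4-dichlorophenyl on the carbonyl carbon. In this assay compound 2 gives > 100000 nM, again a limit of the assay. The step that the two limits leave unreadable from compound 1 to compound 2 cannot be read, since both ends sit at the limit of > 100000 nM in this assay, at which 2 of the 2 values shown sit; on the numbers shown, compound 2 stands at that limit and nowhere else.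

Compound 3 `O=C(Nc1ccc(Cl)c(-c2nnc3c(Cl)cccn23)c1)c1ccon1` is not yet measured. It differs from compound 2 by 1,2-oxazol-3-yl in place of 2,4-dichlorophenyl on a carbonyl carbon. Within the data shown here, no measured step bears on this change: the only step in the set, from a 3-chlorophenyl to a 2,4-dichlorophenyl, is unreadable because both of its values sit at the limit of > 100000 nM in this assay, at which 2 of the 2 values shown sit. With every measured value at the limit, nothing in the set points to activity appearing in compound 3; the expected step is a number no higher from compound 2 to compound 3 (the limit leaves the size open), that is, none beyond the scatter. Compound 3 is therefore estimated at 100000 nM in this assay, with a range from 30000 nM to 300000 nM, and most probably it will again be reported only as a limit.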

Compound 3, half-maximal inhibitory concentration: > 100000 nM
Compound 3: a limit, no number (the forecaster's own chance of this, stated with the estimate: 80%); the middle value lies on the limit itself.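

No step can be read among compound 1, compound 2 and compound 3, neither for the 1,2-oxazol-3-yl nor for the 2,4-dichlorophenyl change, as all three values are limits and not numbers: the limit of > 100000 nM in this assay, at which 3 of the 3 values shown sit.

The compounds shown leave open whether any group on the carbonyl carbon brings measurable activity to the shared core, and how these three groups rank.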